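Removing the Boronic Acid from a Pyrrole Chalcone

A few compounds are considered here, and "the series" means these few. Any claim that something is new, unique, unknown or untested is made for them only; others in the source may bear on it.

Of the compounds shown here, three have been tested in a functional assay on MDA-MB-231 cells (Homo sapiens) for inhibition; a higher number here means a weaker inhibitor, a lower number a stronger inhibitor. Compound 1 `O=C(/C=C/c1ccc(B(O)O)cc1)c1ccc[nH]1` gives 23000 nM, compound 2 `O=C(/C=C/c1ccc(F)c(Cl)c1)c1ccc(B(O)O)cc1` gives 8500 nM, and compound 3 `O=C(/C=C/c1ccc(I)cc1)c1ccc(OCB(O)O)cc1` gives 11000 nM. Compound 1 has the highest number of the three, and its gaps to compound 2 and to compound 3 both lie beyond the usual scatter, so it is the weakest inhibitor measured so far. Compound 4 `O=C(/C=C/c1ccccc1)c1ccc[nH]1` has not yet been measured in this assay. It differs from compound 1 in one place: a hydrogen atom in place of a group of 3 heavy atoms (1 boron, 2 oxygen; no ring), on an aromatic carbon. Among the measured compounds shown here, no measured pair shows what removing such a group does, so the size of the step is uncertain; a modest loss rather than a gain is expected. Compound 4 is estimated to give about 35000 nM, within 12000 nM to 100000 nM, which would mean an expected step of a 1.5-fold higher number from compound 1 to compound 4 (0.18 log units; within the scatter).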

Compound 4, half-maximal inhibitory concentration: 15000 nM
Beside the measured number, compound 4's estimate is 2.3-fold (0.37 log units) above it; measured number inside the range.
By their numbers in this assay, from the lowest: compounds 2, 3, 4 and 1 (each within the scatter of the next, the first and the last beyond it).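

In this assay, putting a hydrogen atom in place of the boronic acid group gives a 1.5-fold lower number from compound 1 to compound 4 (0.19 log units; within the scatter), so the two compounds cannot be told apart. Among the compounds shown here, for this pair, then, the boronic acid group is not needed for the inhibition seen, the first direct look at this position. No measurement available here accounts for this result. As far as these compounds go, whether a carboxylic acid or an amine at the same place would shift the number remains open. So does whether removing the boronic acid group from compound 2 would give a step of similar size.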